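A few compounds are considered here, and "the series" means these few. Any claim that something is new, unique, unknown or untested is made for them only; others in the source may bear on it.

Three measured compounds share one core and differ only in the group carried on an aromatic nitrogen of a five-membered aromatic ring with 3 nitrogen. Compound 1 `COc1ccccc1-n1cc(COc2c(/C=C\C(=O)O)ccc(OC)c2CC=C(C)C)nn1` carries a 2-methoxyphenyl there; in a functional assay on NCI-H322 cells (Homo sapiens) for cytotoxicity, read by MTT assay, with a stated time of 24 h (on this read-out higher numbers stand for weaker inhibition and lower numbers for stronger inhibition), compound 1 gives 41500 nM. Compound 2 `COc1cccc(-n2cc(COc3c(/C=C\C(=O)O)ccc(OC)c3CC=C(C)C)nn2)c1` carries a 3-methoxyphenyl, and in this assay compound 2 gives 25200 nM. For the measured compounds named here, compound 3 `COc1ccc(/C=C\C(=O)O)c(OCc2cn(-c3ccc(C#N)cc3)nn2)c1CC=C(C)C` carries a 4-cyanophenyl; in this assay compound 3 gives 18600 nM, the lowest of the three numbers, although its gap to compound 2 is within the scatter and only the step of a 2.2-fold lower number from compound 1 to compound 3 (0.35 log units; beyond the scatter) is beyond it.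

Compound 4 `COc1ccc(/C=C\C(=O)O)c(OCc2cn(-c3ccccc3C#N)nn2)c1CC=C(C)C` has not yet been measured. It differs from compound 3 in that (2-cyanophenyl in place of 4-cyanophenyl on an aromatic nitrogen). Going by the values given here, two measured steps bear on this change. The step of a 1.6-fold lower number from compound 1 to compound 2 (0.22 log units; within the scatter) shows how little it mattered where a methoxy sat on this phenyl, and the step of a 1.4-fold lower number from compound 2 to compound 3 (0.13 log units; within the scatter) shows that exchanging a methoxyphenyl for a cyanophenyl also stayed within the scatter. Moving the nitrile on the phenyl is therefore expected to give at most a small step in this assay, if any, leaning toward a slightly higher number. For the step from compound 3 to compound 4 the expected size is a 1.3-fold higher number from compound 3 to compound 4 (0.13 log units; within the scatter). Compound 4 is thus estimated at 25000 nM, within a range from 12000 nM to 55000 nM.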

Compound 4, half-maximal inhibitory concentration: 14400 nM
Compound 4: middle estimate off by 1.7-fold (0.24 log units), on the high side, within the range that was stated.
By their numbers in this assay, from the lowest: compounds 4, 3, 2 and 1 (each within the scatter of the next, the first and the last beyond it).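

For the compounds shown here, compound 4 is the first case in which only the place of the nitrile on the phenyl changes, and in this assay that move gives a 1.3-fold lower number from compound 3 to compound 4 (0.11 log units; within the scatter), so the 2-cyanophenyl and the 4-cyanophenyl cannot be told apart here. Going by these compounds alone, it also gives the first direct exchange of methoxy for cyano on the same aromatic carbon, and that change gives a 2.9-fold lower number from compound 1 to compound 4 (0.46 log units; beyond the scatter), a modest step beyond the scatter, while the exchange of the 3-methoxyphenyl for the 2-cyanophenyl gives a 1.8-fold lower number from compound 2 to compound 4 (0.24 log units; within the scatter), which stays within it. Both nitrile compounds therefore stand apart only from compound 1, and nothing shown here gives a reason for these numbers.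

The compounds shown leave open whether a 3-cyanophenyl would fall in the same narrow band, which would complete the set of nitrile placements on this phenyl. They also leave open whether a very different group on the phenyl, such as an amine or a carboxylic acid, would move the number further than any exchange seen so far.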